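Swapping a methoxy for trifluoromethyl on the ring system

The source may report more compounds than this note shows. Statements on the series, on what has been measured and on what is new or still open speak of the compounds shown alone.

Measured compounds:
- compound 1, `Cc1ccc2nc(C(=O)Nc3c(F)cc(-c4cccc(F)c4)cc3F)c(C)c(C(=O)O)c2c1`: 75.2%
- compound 2, `COc1ccc2nc(C(=O)Nc3c(F)cc(-c4cccc(F)c4)cc3F)c(C)c(C(=O)O)c2c1`: 28.3%

In a functional assay on Hep 3B2 cells (Homo sapiens) for antiproliferative activity, read by MTT assay, with a stated time of 24 h, tested at 100 ug/mL (on this read-out lower numbers stand for a weaker effect and higher numbers for a stronger effect at the one concentration tested), compound 2 gives the lower of the two numbers; compound 1 gives 75.2% in this assay. Among the compounds with values here, the one step measured so far runs a number 46.9 percentage points lower from compound 1 to compound 2 (beyond the scatter), a large loss when methoxy replaced methyl on an aromatic carbon. Compound 3, `Cc1c(C(=O)Nc2c(F)cc(-c3cccc(F)c3)cc2F)nc2ccc(C(F)(F)F)cc2c1C(=O)O`, is not yet measured; it differs from compound 2 by trifluoromethyl in place of methoxy on an aromatic carbon. Within the data shown here, no measured step involves trifluoromethyl, so the only guide is that compound 2 with the methoxy group gave 28.3% while compound 1 without it gave a much higher number. Removing the methoxy group is therefore expected to recover part of that loss, giving an upward step a number 26.7 percentage points higher from compound 2 to compound 3 (beyond the scatter) in this assay. Among the measured compounds shown here, compound 3 is thus estimated at 55%, between 30% and 80%, with wide uncertainty because only one step is known.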

Compound 3, a percentage reported as inhibition, at one concentration (the size of the read-out at that concentration, not a potency): 72.3%
Estimate against measurement, compound 3: 17.3 percentage points below, within the range that was stated.
By their numbers in this assay, from the lowest: compound 2; then compounds 3 and 1 (each within the scatter of the next).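

In this assay, trifluoromethyl in place of methoxy on an aromatic carbon gives a number 44 percentage points higher from compound 2 to compound 3 (beyond the scatter), so the low number of compound 2 does not extend to every replacement of methyl at this place. Trifluoromethyl in place of methyl gives a number 2.9 percentage points lower from compound 1 to compound 3 (within the scatter), which means that these two groups cannot be told apart here, while methoxy stands apart from both. The heavy-atom count alone does not sort these results, since trifluoromethyl, with 4 heavy atoms, falls with methyl rather than with methoxy, which has 2.

On these data alone, it remains open whether an amine, a nitrile or a longer chain at this place would fall with methoxy or with methyl and trifluoromethyl. Nothing available here explains why methoxy differs from the other two groups.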